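The source may report more compounds than this note shows. Statements on the series, on what has been measured and on what is new or still open speak of the compounds shown alone.

Compound 1 `O=c1cc(CNCc2ccccc2I)oc2ccc(O)c(O)c12` gives 87300 nM in an ADME assay on Huh-7 cells (Homo sapiens) for cytotoxicity; a lower number here means that less compound is tolerated, a higher number that more compound is tolerated. Compound 2 `O=c1cc(CNCc2ccccc2O)oc2ccc(O)c(O)c12` differs from compound 1 by hydroxy in place of iodo on an aromatic carbon. For compound 2 this assay reports only a limit, > 100000 nM, and the limit of > 100000 nM in this assay, at which 1 of the 3 values shown sits, marks where the measurement stops. The change thus gave an at least 1.1-fold higher number from compound 1 to compound 2 (0.05 log units; that floor lies within the scatter). Compound 3 `O=c1cc(CNCc2ccc(I)cc2)oc2ccc(O)c(O)c12` has the same atoms as compound 1 joined differently, namely (4-iodophenyl in place of 2-iodophenyl on a saturated chain carbon bound to an amine nitrogen), and in this assay compound 3 gives 41700 nM, which is a 2.1-fold lower number from compound 1 to compound 3 (0.32 log units; beyond the scatter). Compound 4 `O=c1cc(CNCc2ccc(O)cc2)oc2ccc(O)c(O)c12` carries the same kind of change applied to compound 3, (hydroxy in place of iodo on an aromatic carbon), the place now reading para to a large group rather than ortho to a large group. Resting on the earlier step of an at least 1.1-fold higher number from compound 1 to compound 2 (0.05 log units; that floor lies within the scatter), which ran into a limit, the expected step is a 2.2-fold higher number from compound 3 to compound 4 (0.33 log units; beyond the scatter). Compound 4 is accordingly estimated at 90000 nM, between 45000 nM and 200000 nM.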

Compound 4, half-maximal cytotoxic concentration: 62700 nM
Estimate against measurement, compound 4: 1.4-fold (0.16 log units) above, within the range that was stated.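

In this assay, hydroxy in place of iodo gives a 1.5-fold higher number from compound 3 to compound 4 (0.18 log units; within the scatter), and the change from 2-iodophenyl to 4-hydroxyphenyl gives a 1.4-fold lower number from compound 1 to compound 4 (0.14 log units; within the scatter). Whether the hydroxy for iodo change carries over from one core to the other with the same size is not shown: the same change on two cores in this assay, an at least 1.1-fold higher number (0.05 log units; that floor lies within the scatter) from compound 1 to compound 2 and a 1.5-fold higher number (0.18 log units; within the scatter) from compound 3 to compound 4; the limit leaves it open whether they differ The step between the two hydroxy isomers gives an at least 1.5-fold lower number from compound 2 to compound 4 (0.20 log units; that floor lies within the scatter), which is only a floor set by a limit: the limit of > 100000 nM in this assay, at which 1 of the 4 values shown sits.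

The compounds shown leave open how an amine or a carboxylic acid would read in this assay in place of the hydroxy. They also leave open whether a methoxy or a fluoro group would fall with hydroxy or with iodo.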